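The source may report more compounds than this note shows. Statements on the series, on what has been measured and on what is new or still open speak of the compounds shown alone.

Compound 1 `Nc1ccn(C2OC(CO)C(Br)C2O)c(=O)n1` is tested in a functional assay on L5178Y cells (Mus musculus) for antiproliferative activity (a lower number here means a stronger inhibitor, a higher number a weaker inhibitor), where compound 1 gives 0.03 ug/mL. This is the lowest of the two numbers at hand; the nearest is compound 2 `Nc1nc(=O)n(C2OC(CO)C(Br)C2O)cc1F`, which gives 0.06 ug/mL in this assay, a move of a 2.0-fold higher number from compound 1 to compound 2 (0.30 log units; within the scatter) for fluoro in place of hydrogen on an aromatic carbon, within the scatter. Compound 3 `Nc1ccn(C2OC(CO)C(Cl)C2O)c(=O)n1` differs from compound 1 by chloro in place of bromo on a saturated ring carbon. Among the measured compounds shown here, that change sits on the saturated ring carbon, not the aromatic carbon, so no measured step bears on it. No step beyond the scatter is expected, a 1.7-fold higher number from compound 1 to compound 3 (0.22 log units; within the scatter). Compound 3 is therefore estimated at 0.05 ug/mL, within 0.012 ug/mL to 0.25 ug/mL in this assay.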

Compound 3, concentration for 50% inhibition: 2 ug/mL
Compound 3: middle estimate off by 40-fold (1.60 log units), on the low side; measured number above the stated range.
By their numbers in this assay, from the lowest: compounds 1 and 2 (each within the scatter of the next); then compound 3.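

Exchanging one halogen for another on this saturated ring carbon is not a neutral change: in this assay, chloro in place of bromo gives a large step (a 67-fold higher number from compound 1 to compound 3 (1.82 log units; beyond the scatter)). Among the compounds shown here, the number at this position therefore depends strongly on which halogen is present, whereas the only earlier step, on the aromatic carbon, stayed within the scatter. No measurement at hand explains this difference between bromo and chloro. The compounds shown leave open how iodo, an amine or a methoxy group would fare at this position, and whether the aromatic fluoro would change the result when chloro sits on the saturated ring carbon.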